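The compounds below may be only part of what the source reports. "The series", "measured", "known", "first", "only" and "open" are said of these compounds alone.

Measured in a functional assay on CEM-DNR-bulk cells (Homo sapiens), read by MTT assay, with a stated time of 72 h (a lower number here means a stronger inhibitor, a higher number a weaker inhibitor), each value a limit and not a number:
- compound 1 (`COc1ncnc2c1c(-c1ccccc1)cn2[C@@H]1O[C@H](CO)[C@@H](O)[C@H]1O`) gives > 20000 nM
- compound 2 (`COc1nc(N)nc2c1c(-c1ccoc1)cn2[C@@H]1O[C@H](CO)[C@@H](O)[C@H]1O`) gives > 20000 nM
- compound 3 (`COc1nc(N)nc2c1c(-c1cccs1)cn2[C@@H]1O[C@H](CO)[C@@H](O)[C@H]1O`) gives > 20000 nM

Compound 3 stands only at a limit in this assay, as the other two do (the limit of > 20000 nM in this assay, at which 3 of the 3 values shown sit). Compound 4 (`COc1nc(N)nc2c1c(-c1ccccc1)cn2[C@@H]1O[C@H](CO)[C@@H](O)[C@H]1O`) carries phenyl in place of thiophen-2-yl on an aromatic carbon. Among the compounds with values here, the one measured step of this kind puts thiophen-2-yl in place of furan-3-yl (a step that the two limits leave unreadable from compound 2 to compound 3), and it gives no size. Compound 1 also carries phenyl, and its value (> 20000 nM) is a limit too. The expectation rests on compound 3, whose value (> 20000 nM) is a limit. No step beyond the scatter is expected in this assay, in either direction (a number no higher from compound 3 to compound 4 (the limit leaves the size open)). The estimate for compound 4 is 20000 nM (expected range 10000 nM to 40000 nM).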

Compound 4, half-maximal inhibitory concentration: > 20000 nM
Compound 4 ended at the assay's limit; the forecaster's own chance of this, stated with the estimate: 85%; the middle value sits exactly at the limit.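

No step can be read from compound 1, compound 2 or compound 3 to compound 4, as all four values are limits and not numbers. Whether phenyl, thiophen-2-yl, furan-3-yl or the amino group changes potency at all stays open: the limit of > 20000 nM in this assay, at which 4 of the 4 values shown sit.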